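Replacing a methoxy by a methyl on the aryl ring

The compounds below may be only part of what the source reports. "The series", "measured", "known", "first", "only" and "open" are said of these compounds alone.

These compounds share one core, and they differ only in what sits on the phenyl ring attached to the cyclopropane. Compound 1, `CC[C@H](C)[C@H](N)CN(C(=O)[C@@H]1C[C@H]1c1ccccc1)c1ccc(-c2ccccc2)cc1`, carries an unsubstituted ring. Compound 2, `CC[C@H](C)[C@H](N)CN(C(=O)[C@@H]1C[C@H]1c1cccc(OC)c1)c1ccc(-c2ccccc2)cc1`, carries a methoxy group on that ring. The unmeasured compound 3, `CC[C@H](C)[C@H](N)CN(C(=O)[C@@H]1C[C@H]1c1cccc(C)c1)c1ccc(-c2ccccc2)cc1`, carries a methyl group instead.

In a functional assay for agonist activity at G protein-coupled receptor 88 (Homo sapiens), read by HTRF and cAMP accumulation (on this read-out higher numbers stand for an effect only at larger amounts of compound and lower numbers for an effect already at smaller amounts), compound 1 gives 230 nM; 800 nM (2 entries). In this assay, within the data shown here, compound 2 gives 3000 nM, the only number recorded for it; one further entry for compound 2 yields no single number. Of the two, the values of compound 2 are the larger.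

The change from compound 2 to compound 3 is methyl in place of methoxy on an aromatic carbon. Among the measured compounds shown here, no measured pair shows this exact change, so its effect is uncertain. A small step toward smaller numbers is expected, close to the usual scatter, written as a 2.0-fold lower number from compound 2 to compound 3 (0.30 log units; within the scatter). Compound 3 is therefore estimated at 1500 nM, with a plausible range from 500 nM to 5000 nM.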

Compound 3, half-maximal effective concentration: 1200 nM
Beside the measured number, compound 3's estimate is 1.3-fold (0.10 log units) above it; the measured number falls inside the stated range.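

In this assay, among these compounds, putting methyl in place of methoxy on this aromatic carbon gives a 2.5-fold lower number from compound 2 to compound 3 (0.40 log units; beyond the scatter), a modest change but the first direct evidence that the group at this position affects the read-out. The step also shows that replacing methoxy does not, on these numbers, take the compound clearly beyond the unsubstituted ring, since compound 3 at 1200 nM lies close to the upper entry of compound 1 and well away from its lower one. Whether compound 3 really differs from compound 1 therefore stays unsettled, and the comparison is only as firm as its reference, which is spread across the values here: the several entries of compound 1 in this assay, 230 nM; 800 nM (2 entries)

The compounds shown hold only methoxy, methyl or nothing on this ring, so how a chlorine, a trifluoromethyl or an amine at the same carbon would read remains open. On these data alone, it is also open whether the step from methoxy to methyl would look the same on another carbon of this ring, or on a core with a different group in place of the biphenyl-like part.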